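The source may report more compounds than this note shows. Statements on the series, on what has been measured and on what is new or still open speak of the compounds shown alone.

Compound 1 `COC(=O)[C@@]1(C)CCC=C2[C@@H]1CC[C@@H](C)[C@]2(C)Cc1c[nH]c2c(C)cccc12` and compound 2 `COC(=O)[C@@]1(C)CCC=C2[C@@H]1CC[C@@H](C)[C@]2(C)Cc1c[nH]c2c(Br)cccc12` share one core, while compound 3 `COC(=O)[C@@]1(C)CCC=C2[C@@H]1CC[C@@H](C)[C@]2(C)Cc1c(C)[nH]c2ccc(C)cc12` and compound 4 `COC(=O)[C@@]1(C)CCC=C2[C@@H]1CC[C@@H](C)[C@]2(C)Cc1c(C)[nH]c2ccc(Br)cc12` share another; the difference between the two cores is not broken down here. In a functional assay on SW1573 cells (Homo sapiens) for inhibition, read by sulforhodamine B assay, with a stated time of 48 h (on this read-out lower numbers stand for stronger inhibition of growth and higher numbers for weaker inhibition of growth), compound 1 gives 7800 nM, compound 2 gives 14000 nM and compound 3 gives 18000 nM. The change from compound 1 to compound 2 is bromo in place of methyl on an aromatic carbon, and it made a 1.8-fold higher number from compound 1 to compound 2 (0.25 log units; within the scatter). The change from compound 3 to compound 4 is bromo in place of methyl on an aromatic carbon, the same kind of change, although the bromo here sits meta to a fused ring and para to a fused ring rather than ortho to a fused ring and meta to a fused ring. Because the earlier step was a 1.8-fold higher number from compound 1 to compound 2 (0.25 log units; within the scatter), a step of similar size is expected, a 1.4-fold higher number from compound 3 to compound 4 (0.14 log units; within the scatter). Compound 4 is therefore estimated at 25000 nM in this assay, with a likely range from 12000 nM to 50000 nM.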

Compound 4, concentration for 50% growth inhibition: 14000 nM
Estimate against measurement, compound 4: 1.8-fold (0.25 log units) above, within the range that was stated.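

On the second core, bromo in place of methyl made a 1.3-fold lower number from compound 3 to compound 4 (0.11 log units; within the scatter) in this assay. Set beside the same change on the first core, the two steps cannot be told apart: the same change on two cores in this assay, a 1.8-fold higher number (0.25 log units; within the scatter) from compound 1 to compound 2 and a 1.3-fold lower number (0.11 log units; within the scatter) from compound 3 to compound 4, 2.3-fold (0.36 log units) apart, within the scatter of two such steps So the swap stays within the scatter on both cores, but this does not show that its direction carries over, and two pairs, with the bromo in a different place on each core, give no rule for the series.

The compounds shown leave open how a methoxy group, an amine or a carboxylic acid would behave on these aromatic carbons. They also leave open whether a carboxylic acid in place of the methyl ester would change growth inhibition.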